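Swapping 4-hydroxyphenyl for 2,4-dichlorophenyl

A few compounds are considered here, and "the series" means these few. Any claim that something is new, unique, unknown or untested is made for them only; others in the source may bear on it.

Compound 1 `O=C(Cc1csc2nc(-c3ccc(Br)cc3)cn12)N/N=C/c1ccccc1`: 12900 nM
Compound 2 `O=C(Cc1csc2nc(-c3ccc(Br)cc3)cn12)N/N=C/c1ccc(O)cc1`: 10500 nM

Going by the values given here, in a functional assay on MDA-MB-231 cells (Homo sapiens) for inhibition, read by sulforhodamine B assay, with a stated time of 48 h (on this read-out lower numbers stand for stronger inhibition of growth and higher numbers for weaker inhibition of growth), compound 2 stands level with compound 1, the only other measured compound. Among the compounds with values here, the single measured step is a 1.2-fold lower number from compound 1 to compound 2 (0.09 log units; within the scatter). Compound 3 `O=C(Cc1csc2nc(-c3ccc(Br)cc3)cn12)N/N=C/c1ccc(Cl)cc1Cl` carries 2,4-dichlorophenyl in place of 4-hydroxyphenyl on a carbon with a double bond to nitrogen. Within the data shown here, only that one step bears on this change, and it concerns hydroxy in place of hydrogen, not chlorine. Among the measured compounds shown here, no measured compound has chlorine on this ring, so the data give little guide to direction, and no change beyond the scatter is expected. The expected step is a 1.3-fold lower number from compound 2 to compound 3 (0.12 log units; within the scatter). For compound 3 the estimated value is 8000 nM, with an expected range of 2500 nM to 25000 nM.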

Compound 3, concentration for 50% growth inhibition: 26300 nM
For compound 3 the middle estimate is 3.3-fold (0.52 log units) below the measured one; measured number above the stated range.
By their numbers in this assay, from the lowest: compounds 2 and 1 (each within the scatter of the next); then compound 3.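

In this assay, the group on the carbon with a double bond to nitrogen does matter: 2,4-dichlorophenyl weakens growth inhibition relative to both 4-hydroxyphenyl (a 2.5-fold higher number from compound 2 to compound 3 (0.40 log units; beyond the scatter)) and plain phenyl (a 2.0-fold higher number from compound 1 to compound 3 (0.31 log units; beyond the scatter)). Both steps are modest but beyond the scatter, whereas the earlier hydroxy change was not. Nothing available here accounts for this loss.

Going by these compounds, whether both chlorines are needed for the step, or one alone gives it, remains open. So does the effect of an amine or a carboxylic acid on this ring.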